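This account rests on a few compounds, and the source may have more. Where it says the series, first, only, none or still open, it means among the compounds named here.

Measured compounds in a functional assay on CCRF-CEM cells (Homo sapiens); on this read-out higher numbers stand for weaker inhibition and lower numbers for stronger inhibition:

Compound 1 `N#C[C@H]1[C@@H](O)[C@H](n2cc(F)c(O)nc2=O)O[C@H](CO)[C@H]1O` — only a limit, > 500000 nM
Compound 2 `N#C[C@H]1[C@@H](O)[C@H](n2ccc(O)nc2=O)O[C@H](CO)[C@H]1O` — only a limit, > 500000 nM
Compound 3 `Cc1cn([C@@H]2O[C@H](CO)[C@@H](O)[C@@H](C#N)[C@H]2O)c(=O)nc1O` — only a limit, > 750000 nM

Compound 2 stands at a limit of this assay, and the two other values shown are limits as well, so no number places it against them. Its value of > 500000 nM is a limit and not a measured point. The step to compound 4 `N#C[C@H]1[C@@H](O)[C@H](n2ccc(N)nc2=O)O[C@H](CO)[C@H]1O` is this: amino in place of hydroxy on an aromatic carbon.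

Three measured steps could bear on this change, and all three are unreadable. The step that the two limits leave unreadable from compound 1 to compound 2 cannot be sized because the limit of > 500000 nM in this assay, at which 2 of the 3 values shown sit, holds both of its values. The steps a step that the two limits leave unreadable from compound 1 to compound 3 and a step that the two limits leave unreadable from compound 2 to compound 3 cannot be sized because the limit of > 750000 nM in this assay, at which 1 of the 3 values shown sits, fixes compound 3 at a limit as well. Going by the values given here, no measured step in this set changes the hydroxy itself, so no readable size is available for amino in place of hydroxy on an aromatic carbon in this assay.

The estimate for the step from compound 2 to compound 4 is therefore a guess without a measured anchor, and the step of an at least 1.6-fold lower number from compound 2 to compound 4 (0.22 log units; that floor lies within the scatter) is expected to be reported as no readable size if compound 4 again sits at a limit. Compound 4 is expected to give about 300000 nM, with a range from 10000 nM to 1000000 nM.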

Compound 4, half-maximal inhibitory concentration: > 750000 nM
Compound 4 was reported as a limit (the forecaster's own chance of this, stated with the estimate: 60%); middle value at least 2.5-fold (0.39 log units) from the limit.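

In this assay compound 4 gives > 750000 nM, which is a limit. Compound 2 gives > 500000 nM, also a limit, so no size can be read for the step between compound 2 and compound 4. The compounds shown leave open how much amino in place of hydroxy on an aromatic carbon changes inhibition in this assay, if at all.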